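A few compounds are considered here, and "the series" means these few. Any claim that something is new, unique, unknown or untested is made for them only; others in the source may bear on it.

Compound 1 `CSS[C@H]1C[C@H](n2ccc(N)nc2=O)O[C@@H]1CO`: < 0.0834 h
Compound 2 `C=CCSS[C@H]1C[C@H](n2cc(C)c(=O)[nH]c2=O)O[C@@H]1CO`: < 0.0834 h
Compound 3 `CCCCCCCCSS[C@H]1C[C@H](n2cc(C)c(=O)[nH]c2=O)O[C@@H]1CO`: < 0.0834 h

These three compounds were tested in a physicochemical assay for pharmacokinetics, at pH 7.2 (a higher number here means that the compound lasts longer, a lower number that the compound disappears faster), and none of them gave an exact number. Compound 2 stands at < 0.0834 h, which is a limit and not a measured half-life. The other two compounds offer no firmer reference point, as the whole set shares one result: the limit of < 0.0834 h in this assay, at which 3 of the 3 values shown sit.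

The unmeasured compound 4 `Cc1cn([C@H]2C[C@H](SSCCO)[C@@H](CO)O2)c(=O)[nH]c1=O` keeps the core of compound 2 and differs from it in one place: hydroxymethyl in place of vinyl on a saturated chain carbon bound to a sulfur. In words, this is hydroxymethyl in place of vinyl on a saturated chain carbon bound to a sulfur.

For the measured compounds named here, only one measured step changes this same place: a step that the two limits leave unreadable from compound 2 to compound 3. That step puts heptyl in place of vinyl, but it gives no size to build on. With no readable shift to carry over, no step beyond the usual scatter is expected in this assay, and the expected outcome is a step that the limit leaves unreadable from compound 2 to compound 4. For compound 4 the estimated half-life is 0.05 h, with an expected range from 0.02 h to 0.1 h.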

Compound 4, half-life: < 0.0834 h
Compound 4: only a limit was reported; the forecaster's own chance of this, stated with the estimate: 85%; the middle value lies beyond the limit too.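

Compound 4 gives only a limit, so its steps from compound 2 and compound 3 cannot be read, and all the compounds share one result: the limit of < 0.0834 h in this assay, at which 4 of the 4 values shown sit.

How long any of these compounds lasts in this assay stays open, as does whether changing the chain on the sulfur alters that time at all.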